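The compounds below may be only part of what the source reports. "The series", "measured", "known", "first", "only" and "open" are said of these compounds alone.

Measured compounds:
Compound 1 `COc1ccc(C#Cc2ccc(C(=O)N3CCCC(OC)C3)cc2)cc1`: in a functional assay on HEK293 cells for negative allosteric modulation of metabotropic glutamate receptor 2 (Rattus norvegicus), read by calcium flux, with a stated time of 2.5 min (a lower number here means a stronger inhibitor, a higher number a weaker inhibitor), compound 1 gives > 30000 nM, which is a limit of the assay.
Compound 2 `COc1ccc(C#Cc2ccc(C(=O)N3CCC(CO)C3)cc2)cc1`: in this assay compound 2 gives > 30000 nM, again a limit.
Compound 3 `COc1ccc(C#Cc2ccc(C(=O)N3CCC[C@@H](O)C3)cc2F)cc1`: in this assay compound 3 gives > 30000 nM, also a limit.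

Compound 2 therefore stands at the limit rather than at a number, and the two further values shown are limits as well; the whole set sits at the limit of > 30000 nM in this assay, at which 3 of the 3 values shown sit. Among the compounds with values here, the only step between measured compounds that differ in one place, a step that the two limits leave unreadable from compound 1 to compound 2, cannot be read, because both of its ends are limits. Within the data shown here, compound 3 forms no single-change pair with compound 2, so its value shows only that it is a limit too.

Compound 4 `COc1ccc(C#Cc2ccc(C(=O)N3CC4CCC(O)C4C3)cc2)cc1` differs from compound 2 by a group of 9 heavy atoms (7 carbon, 1 nitrogen, 1 oxygen; one five-membered non-aromatic ring of carbon only, one five-membered non-aromatic ring with 1 hetero atom) in place of a group of 7 heavy atoms (5 carbon, 1 nitrogen, 1 oxygen; one five-membered non-aromatic ring with 1 hetero atom), on a carbonyl carbon. Among the measured compounds shown here, no measured step bears on this change, and the one step that exists has no readable size. Nothing among the three values points towards a readable number. The expectation for compound 4 in this assay is therefore another limit, and the estimate for compound 4 is 30000 nM, with a range from 10000 nM to 100000 nM. The step implied by this estimate, a number no higher from compound 2 to compound 4 (the limit leaves the size open), is expected to be none beyond the scatter.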

Compound 4, half-maximal inhibitory concentration: > 30000 nM
Compound 4: a limit, no number (the forecaster's own chance of this, stated with the estimate: 80%); the middle value lies on the limit itself.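

In this assay compound 4 gives > 30000 nM, which is a limit of the assay and not a number. The steps to compound 4 from compound 1 and from compound 2 therefore cannot be read. The compounds shown leave open whether any group on the carbonyl carbon gives a readable value: the limit of > 30000 nM in this assay, at which 4 of the 4 values shown sit.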